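Chloro for Hydrogen on a Phenyl: Cytotoxicity Outlook

This account rests on a few compounds, and the source may have more. Where it says the series, first, only, none or still open, it means among the compounds named here.

Compound 1 `C/C(=N\NC(N)=O)c1ccc2[nH]c(-c3ccccc3)nc2c1` and compound 2 `C/C(=N\NC(N)=O)c1ccc2[nH]c(-c3ccc(Cl)cc3)nc2c1` share one core, while compound 3 `CC(=O)c1ccc2c(c1)nc(-c1ccccc1)n2C1CCCCC1` and compound 4 `CC(=O)c1ccc2c(c1)nc(-c1ccc(Cl)cc1)n2C1CCCCC1` share another; the difference between the two cores is not broken down here. In an ADME assay on BHK-21 cells (Mesocricetus auratus) for cytotoxicity, read by MTT assay (a lower number here means that less compound is tolerated, a higher number that more compound is tolerated), compound 1 gives > 100000 nM, which is a limit of the assay. Compound 2 likewise gives > 100000 nM in this assay, again a limit. Among the compounds with values here, compound 3 gives 100000 nM in this assay, the only number among the three values. The change from compound 1 to compound 2 is chloro in place of hydrogen on an aromatic carbon, and its step is a step that the two limits leave unreadable from compound 1 to compound 2. Compound 4 carries the same change made on the core of compound 3, namely (chloro in place of hydrogen on an aromatic carbon). Both values of the pair that has already seen this change sit at the limit of > 100000 nM in this assay, at which 2 of the 3 values shown sit, so that earlier step cannot be read. The step now expected is estimated as no change at the digits printed from compound 3 to compound 4 (within the scatter). That expectation rests on compound 3 standing at 100000 nM. It rests also on the change from compound 1 to compound 2 having left both members at the same limit, as a step that the two limits leave unreadable from compound 1 to compound 2 shows. Compound 4 is therefore estimated at 100000 nM, with a range from 50000 nM to 200000 nM.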

Compound 4, half-maximal cytotoxic concentration: > 100000 nM
Compound 4 was reported as a limit (the forecaster's own chance of this, stated with the estimate: 50%); the middle value lies on the limit itself.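

On the core of compound 3, the change from phenyl to 4-chlorophenyl gives in this assay a number no lower from compound 3 to compound 4 (the limit leaves the size open). The direction therefore holds up on this second core: the chloro compound does not fall below its partner, and compound 4 reaches the limit of the assay, the same limit that the chloro compound on the other core, compound 2, shows. As far as these compounds go, the step on the other core cannot be read and this one has no size, so it stays unknown whether the change does the same amount on both cores, and most of the set sits at one limit: the limit of > 100000 nM in this assay, at which 3 of the 4 values shown sit.

The compounds shown leave open whether another group at that place, such as an amine, a carboxylic acid or a longer chain, would give a number clear of the limit. Within the data shown here, compound 3 at 100000 nM is the only measured number here, so how far any change can move this read-out also remains open.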